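Bromo for Methoxy on an Aromatic Carbon of Compound 2

A few compounds are considered here, and "the series" means these few. Any claim that something is new, unique, unknown or untested is made for them only; others in the source may bear on it.

Measured compounds:
Compound 1, `COc1ccc(C2=NN(C3=NC(c4ccccc4)CS3)C(c3cccc4ccccc34)C2)cc1`: 8740 nM
Compound 2, `COc1ccc(C2=NN(C3=NC(c4ccccc4)CS3)C(c3ccc4ccccc4c3)C2)cc1`: 12600 nM

In a functional assay on HepG2 cells (Homo sapiens) for inhibition, read by CCK-8 assay, with a stated time of 48 h (on this read-out lower numbers stand for stronger inhibition and higher numbers for weaker inhibition), compound 1 gives 8740 nM and compound 2 gives 12600 nM. Within the data shown here, compound 2 stands at the highest of the two numbers, yet the only measured step, a 1.4-fold higher number from compound 1 to compound 2 (0.16 log units; within the scatter), sits within the scatter, so the two compounds cannot be ordered. Compound 3, `Brc1ccc(C2=NN(C3=NC(c4ccccc4)CS3)C(c3ccc4ccccc4c3)C2)cc1`, differs from compound 2 by bromo in place of methoxy on an aromatic carbon. Among the measured compounds shown here, that measured step concerns a group on a saturated ring carbon, not the aromatic carbon changed here, so no measured step bears on this exchange. With nothing pointing in either direction, no step beyond the scatter is expected for compound 3 in this assay. Compound 3 is therefore expected to give about 12600 nM in this assay, in a range from 4000 nM to 40000 nM. The expected step is no change at the digits printed from compound 2 to compound 3 (within the scatter).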

Compound 3, half-maximal inhibitory concentration: 20300 nM
Beside the measured number, compound 3's estimate is 1.6-fold (0.21 log units) below it, and the stated range covers the measured number.
By their numbers in this assay, from the lowest: compounds 1, 2 and 3 (each within the scatter of the next, the first and the last beyond it).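

In this assay, bromo in place of methoxy on this aromatic carbon gives a 1.6-fold higher number from compound 2 to compound 3 (0.21 log units; within the scatter) and so does not separate the two compounds. Among these compounds, the earlier step concerned only a group on a saturated ring carbon, so this is the first reading at the aromatic carbon, and here the exchange of methoxy, with its hydrogen-bond acceptor, for bromo, with none, leaves the number within the scatter. No measurement on hand accounts for this result.

As far as these compounds go, it remains open whether a group of another kind on this carbon, such as an amine or a carboxylic acid, would move the number beyond the scatter. From the compounds shown here alone, it is also open whether the same exchange would read alike with the naphthalen-1-yl group of compound 1 on the saturated ring carbon.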